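A few compounds are considered here, and "the series" means these few. Any claim that something is new, unique, unknown or untested is made for them only; others in the source may bear on it.

Among the compounds with values here, compound 2, `OC1CCN(Cc2ccccc2)CC1N1CCN(c2ccccc2)CC1`, is one of two compounds measured in an assay on PC-12 cells for displacement of a labelled ligand from vesicular acetylcholine transporter (Homo sapiens); on this read-out lower numbers stand for stronger inhibition and higher numbers for weaker inhibition. In this assay compound 2 gives > 100 nM, and this is a limit of the assay rather than a number. The other measured compound, compound 1 with the structure `C=CCN1CCC(N2CCN(c3ccccc3)CC2)C(O)C1`, is its allyl counterpart. In this assay compound 1 gives > 100 nM, again a limit and not a number. The measured picture is therefore thin: the limit of > 100 nM in this assay, at which 2 of the 2 values shown sit, so neither compound has a value to place it within the range where the assay reports numbers.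

Compound 3, `CCN1CCC(O)C(N2CCN(c3ccccc3)CC2)C1`, has not been measured. It differs from compound 2 by methyl in place of phenyl on a saturated chain carbon bound to an amine nitrogen in a ring. Within the data shown here, no step between measured compounds is known here, so the size of the step from compound 2 to compound 3 in this assay rests only on where compound 2 itself stands. Since compound 2 gives > 100 nM, a limit, it is expected that compound 3 will most likely also fall at or beyond that limit, with the step that the limit leaves unreadable from compound 2 to compound 3 expected to stay within the scatter. Compound 3 is estimated at 300 nM, within 100 nM to 3000 nM.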

Compound 3, half-maximal inhibitory concentration: > 1000 nM
Compound 3 ended at the assay's limit; the forecaster's own chance of this, stated with the estimate: 70%; middle value at least 3.3-fold (0.52 log units) away from the limit.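

Within the data shown here, no step from compound 2 to compound 3 can be read in this assay, since compound 2 gives > 100 nM and compound 3 gives > 1000 nM, each a limit of the assay and not a number. The compounds shown leave open where any of them would fall on a measured scale, and how much the change from benzyl to ethyl matters.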